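This account rests on a few compounds, and the source may have more. Where it says the series, first, only, none or still open, it means among the compounds named here.

Measured so far:
Compound 1 `COc1ccc(N(CC(=O)NCCC[Se]c2ccccc2)C(=O)c2ccccc2)cc1` — in a functional assay on A-431 cells (Homo sapiens) for cytotoxicity, read by MTT assay, with a stated time of 24 h (on this read-out lower numbers stand for stronger inhibition and higher numbers for weaker inhibition), compound 1 gives >= 100000 nM, a limit of the assay.
Compound 2 `COc1ccc(N(CC(=O)NCCCSc2ccccc2)C(=O)/C=C/c2ccccc2)cc1` — in this assay compound 2 gives >= 100000 nM, also a limit.

Compound 2 therefore stands at the limit, and the other value shown sits there as well (the limit of >= 100000 nM in this assay, at which 2 of the 2 values shown sit). Among the compounds with values here, no measured pair differs in one place, so no step size is available.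

Compound 3 `COc1ccc(N(CC(=O)NCCC[Se]c2ccccc2)C(=O)/C=C/c2ccccc2)cc1` carries a group of 7 heavy atoms (6 carbon, 1 selenium; one six-membered aromatic ring of carbon only) in place of a group of 7 heavy atoms (6 carbon, 1 sulfur; one six-membered aromatic ring of carbon only), on a saturated chain carbon, three bonds along the chain from an amide-type nitrogen relative to compound 3's parent, compound 2.

With both measured values at the limit, the expectation for compound 3 is no change beyond the scatter, a step of a number no higher from compound 2 to compound 3 (the limit leaves the size open), and most likely another limit. Compound 3 is estimated at 100000 nM, range 30000 nM to 300000 nM.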

Compound 3, half-maximal inhibitory concentration: >= 100000 nM
Compound 3 gave a limit, no number (the forecaster's own chance of this, stated with the estimate: 85%); the middle value sits exactly at the limit.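

The steps to compound 3 from compound 2 and from compound 1 cannot be read, because every value is a limit: the limit of >= 100000 nM in this assay, at which 3 of the 3 values shown sit.

The compounds shown leave open whether selenium in place of sulfur, or 2-phenylethenyl in place of phenyl, shifts the read-out at all.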